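This account rests on a few compounds, and the source may have more. Where it says the series, first, only, none or still open, it means among the compounds named here.

Notes on the series in an ADME assay on a cell-free system (plasma, Homo sapiens) for metabolic stability, tested at 1 uM; a lower number here means that the compound disappears faster, a higher number that the compound lasts longer. Compound 1 (`C=CC(=O)N[C@H]1CCCN(S(=O)(=O)c2ccc(NC(=O)OCc3ccccc3)cc2)C1`) gives > 6 h, which is a limit of the assay and not a number. Compound 2 (`C=CC(=O)NC1CN(S(=O)(=O)c2ccc(NC(=O)OCc3ccccc3)cc2)C1`) gives > 6 h, again a limit. Compound 3 (`C=CC(=O)NC1CCN(S(=O)(=O)c2ccc(C(=O)N[C@@H]3C[C@H]3c3ccccc3)cc2)CC1`) gives > 6 h, also a limit. Compound 3 therefore has no exact half-life and stands at the limit of > 6 h in this assay, at which 3 of the 3 values shown sit.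

The next compound is compound 4 (`C=CC(=O)NC1CCN(S(=O)(=O)c2ccc(C(=O)NC3CCCc4ccccc43)cc2)CC1`). The change is 1,2,3,4-tetrahydronaphthalen-1-yl in place of 2-phenylcyclopropyl on an amide-type nitrogen. Among the measured compounds shown here, no measured pair covers a change at this place, so the data give no direct guide to its size. For the measured compounds named here, the only anchor is compound 3, whose > 6 h is a limit. No shift beyond the scatter is expected in this assay, in either direction, and the expected outcome is a step that the limit leaves unreadable from compound 3 to compound 4. A limit is also the most likely report for this measurement. The estimated half-life of compound 4 is 8 h, with an expected range from 5 h to 14 h.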

Compound 4, half-life: > 6 h
Compound 4 was reported as a limit; the forecaster's own chance of this, stated with the estimate: 85%; the middle value does not contradict the limit.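

In this assay no step can be read from compound 3 to compound 4, as both are reported only as limits: the limit of > 6 h in this assay, at which 4 of the 4 values shown sit.

The compounds shown leave open the actual half-life of each, and whether 1,2,3,4-tetrahydronaphthalen-1-yl and 2-phenylcyclopropyl on an amide-type nitrogen differ at all.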